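This account rests on a few compounds, and the source may have more. Where it says the series, first, only, none or still open, it means among the compounds named here.

Compound 3 `CC1(C)Cc2c(ccc(C(=O)/C=C/c3ccccc3)c2OCc2ccccc2)O1` is the starting point here. In a functional assay on NCI-H460 cells (Homo sapiens) for antiproliferative activity, read by MTT assay, with a stated time of 48 h (a lower number here means a stronger inhibitor, a higher number a weaker inhibitor), compound 3 gives > 100000 nM, which is a limit of the assay and not a measured number. Compound 4 `CC1(C)Cc2c(ccc(C(=O)/C=C/c3ccc(Br)cc3)c2OCc2ccccc2)O1` has not yet been tested; it differs from compound 3 by bromo in place of hydrogen on an aromatic carbon. Within the data shown here, the only measured step that resembles this change comes from a pair built on a differently arranged core: compound 1 `CC1(C)Cc2c(OCc3ccccc3)ccc(C(=O)/C=C/c3ccccc3)c2O1` and compound 2 `CC1(C)Cc2c(OCc3ccccc3)ccc(C(=O)/C=C/c3ccc(F)cc3)c2O1`. In this assay compound 1 gives > 100000 nM, a limit of the assay. In this assay compound 2 gives 22300 nM. That step, an at least 4.4-fold lower number from compound 1 to compound 2 (0.65 log units; beyond the scatter), shows a fluoro placed para to a large group bringing the number down out of the limit, though its true size is uncertain due to the limit of > 100000 nM in this assay, at which 2 of the 3 values shown sit. Compound 4 carries bromo rather than fluoro, on a different core, so the analogy is loose. By that analogy, the step from compound 3 to compound 4 is expected to be an at least 3.3-fold lower number from compound 3 to compound 4 (0.52 log units; beyond the scatter). Compound 4 is therefore estimated at 30000 nM, with a plausible range from 8000 nM to 150000 nM.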

Compound 4, half-maximal inhibitory concentration: > 100000 nM
Compound 4 gave a limit, no number; the forecaster's own chance of this, stated with the estimate: 30%; middle value at least 3.3-fold (0.52 log units) away from the limit.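

In this assay, among these compounds, compound 3 and compound 4 both stop at a limit of the assay, so no step between them can be read: the limit of > 100000 nM in this assay, at which 3 of the 4 values shown sit. Going by these compounds, what stays open is whether bromo in place of hydrogen changes the number at all on the core of compound 3.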